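This account rests on a few compounds, and the source may have more. Where it says the series, first, only, none or still open, it means among the compounds named here.

Among the compounds with values here, in a functional assay on MT4 cells (Homo sapiens) for cytotoxicity (a lower number here means that less compound is tolerated, a higher number that more compound is tolerated), compound 1 `CC(C)Sc1nc(O)cc(C(C)c2c(Cl)cccc2Cl)n1` gives 117000 nM, the only exact number so far. Compound 2 `CCC(c1cc(O)nc(SC(C)C)n1)c1c(Cl)cccc1Cl` sits at a limit of the assay, > 200000 nM. Within the data shown here, the one measured step, an at least 1.7-fold higher number from compound 1 to compound 2 (0.23 log units; that floor lies within the scatter), puts methyl in place of hydrogen on a saturated chain carbon, not on the sulfur, and its floor lies within the scatter. Compound 3 `CC(c1cc(O)nc(SC2CCCC2)n1)c1c(Cl)cccc1Cl` carries cyclopentyl in place of isopropyl on a sulfur. Among the measured compounds shown here, no measured step touches that sulfur, so nothing beyond the scatter is expected, and the estimated step is a 1.2-fold lower number from compound 1 to compound 3 (0.07 log units; within the scatter). For compound 3 the expected value is 100000 nM, with an estimated range of 40000 nM to 220000 nM.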

Compound 3, half-maximal cytotoxic concentration: 78300 nM
Estimate against measurement, compound 3: 1.3-fold (0.11 log units) above; the measured number falls inside the stated range.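

The sulfur now has a measured step of its own. In this assay, cyclopentyl in place of isopropyl on a sulfur gives a 1.5-fold lower number from compound 1 to compound 3 (0.17 log units; within the scatter), so the larger group with its five-membered non-aromatic ring leaves the number within the scatter. Compound 2 remains a limit, not a number, so its step offers only a floor to set beside this one: the limit of > 200000 nM in this assay, at which 1 of the 3 values shown sits.

Going by these compounds, whether a longer chain or an amine on that sulfur would move the number beyond the scatter remains open.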